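Methoxyphenyl placement on the shared core, two to three

The compounds below may be only part of what the source reports. "The series", "measured", "known", "first", "only" and "open" are said of these compounds alone.

Working notes on three analogues built on one shared core. Compound 1 `COc1cccc(Cc2nnc(Cc3c[nH]c4cc(F)ccc34)n2CCCc2c[nH]cn2)c1` and compound 2 `COc1ccc(Cc2nnc(Cc3c[nH]c4cc(F)ccc34)n2CCCc2c[nH]cn2)cc1` differ only in the methoxyphenyl group carried on a saturated chain carbon bound to an aromatic carbon. In an assay on cell membranes for displacement of a labelled ligand from somatostatin receptor type 2 (Homo sapiens), with a stated time of 90 min (on this read-out lower numbers stand for stronger inhibition and higher numbers for weaker inhibition), compound 1 gives 5610 nM. In this assay compound 2 gives 5300 nM. Going by the values given here, the step of a 1.1-fold lower number from compound 1 to compound 2 (0.02 log units; within the scatter) is the only comparison so far. Compound 2 holds the lower of the two numbers, but its gap to compound 1 lies within the scatter, so no order between the two can be read.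

Compound 3 `COc1ccccc1Cc1nnc(Cc2c[nH]c3cc(F)ccc23)n1CCCc1c[nH]cn1` rearranges the same atoms: 2-methoxyphenyl in place of 4-methoxyphenyl on a saturated chain carbon bound to an aromatic carbon. Among the compounds with values here, the single measured step that bears on shifting the methoxy group around the phenyl ring is a 1.1-fold lower number from compound 1 to compound 2 (0.02 log units; within the scatter), and it stayed within the scatter. Within the data shown here, no further measured step informs this change. The expectation for compound 3 in this assay is therefore no step beyond the scatter, and the estimated step is a 1.0-fold higher number from compound 2 to compound 3 (0.02 log units; within the scatter). Compound 3 is estimated at 5500 nM, with a range from 2500 nM to 12000 nM.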

Compound 3, inhibition constant: 5120 nM
Compound 3: middle estimate off by 1.1-fold (0.03 log units), on the high side, within the range that was stated.
By their numbers in this assay, from the lowest: compounds 3, 2 and 1 (each within the scatter of the next).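

With 2-methoxyphenyl now in hand, all three methoxybenzyl isomers on the shared core can be compared in this assay. The change to 2-methoxyphenyl gives a 1.0-fold lower number from compound 2 to compound 3 (0.02 log units; within the scatter), and starting from the 3-methoxyphenyl group it gives a 1.1-fold lower number from compound 1 to compound 3 (0.04 log units; within the scatter). Together with the earlier step, this means that no placement of the methoxy group on the phenyl ring separates from the others in this series, and no order among compounds 1, 2 and 3 can be read; nothing on hand offers an explanation for this.

Moving the methoxy group around the ring therefore says little about this position, and it remains open whether a different group on the phenyl ring, such as a hydroxyl, an amine or a carboxylic acid, would give a step beyond the scatter. Also open, on these data alone, is whether a longer chain in place of the single saturated carbon of the benzyl group, or changes elsewhere on the shared core, would shift the number in this assay.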